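A few compounds are considered here, and "the series" means these few. Any claim that something is new, unique, unknown or untested is made for them only; others in the source may bear on it.

Measured compounds:
- compound 1, `C[C@H](Nc1nc(N)nc(N)c1C#N)c1cc(=O)n2cc(F)ccc2c1-c1ccccc1`: "not determined" (no result reported)
- compound 2, `C[C@H](Nc1nc(N)nc(N)c1C#N)c1cc(=O)n2cc(F)ccc2c1-c1ccc(F)cc1`: "not determined" (no result reported)
- compound 3, `C[C@H](Nc1ncnc(N)c1C#N)c1cc(=O)n2cc(F)ccc2c1-c1cc(F)cc(F)c1`: 91%

Compound 1 and compound 2 share their core with compound 3 but carry no number in an ADME assay on microsomes from liver (Homo sapiens), read by LC-MS, using NADPH, with a stated time of 30 min, tested at 1 uM; a lower number here means that less of the compound is left, a higher number that more of the compound is left; for compound 1 the assay reports "not determined" (no result reported) and for compound 2 it reports "not determined" (no result reported). Among the measured compounds shown here, compound 3 therefore stands alone: in this assay compound 3 gives 91%, and with no second number in the set there is no step between measured compounds to compare it with. Its value sits close to the upper end of the scale, leaving little room for a rise.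

Compound 4, `C[C@H](Nc1nc(N)nc(N)c1C#N)c1cc(=O)n2cc(F)ccc2c1-c1cc(F)cc(F)c1`, differs from compound 3 by the change (amino in place of hydrogen on an aromatic carbon). For the measured compounds named here, no step in this assay is known for such a change, so its effect can only be guessed. Since compound 3 already gives 91% in this assay, a further rise for compound 4 is expected to be small. Compound 4 is estimated to give 86% in this assay, with a likely range from 68% to 100%. The step from compound 3 to compound 4 that this estimate means, a number 5 percentage points lower from compound 3 to compound 4 (within the scatter), is expected to stay within the scatter of the assay, with a slight downward lean allowed for.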

Compound 4, percent of the compound remaining: 94%
Estimate against measurement, compound 4: 8 percentage points below, and the stated range covers the measured number.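

In this assay, among the compounds shown here, amino in place of hydrogen on the aromatic carbon between two ring nitrogen atoms gives a number 3 percentage points higher from compound 3 to compound 4 (within the scatter) and thus the first readable step in this set. For the compounds shown here, compound 3 and compound 4 cannot be told apart here, so this position takes the amino group with no loss of compound remaining beyond the scatter, and compound 4 stays near the top of the scale at 94%. No supporting measurement bears on the reason for this result.

As far as these compounds go, whether a larger group at this same carbon, such as methyl, methoxy or dimethylamino, would read the same remains open. Steps to compound 1 and compound 2 cannot be read, so it also remains open how the fluorine atoms on the outer aromatic ring bear on this value.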